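The source may report more compounds than this note shows. Statements on the series, on what has been measured and on what is new or still open speak of the compounds shown alone.

In a functional assay on K562 cells (Homo sapiens) for antiproliferative activity, read by MTT assay, with a stated time of 5 days (a higher number here means a weaker inhibitor, a lower number a stronger inhibitor), compound 1 (`COc1ccc(C(=Cc2ccc(OC)c([N+](=O)[O-])c2)C(=O)c2cc(OC)c(OC)c(OC)c2)cc1`) gives 2660000 nM while compound 2 (`COc1ccc(C(=Cc2ccc(OC)c(O)c2)C(=O)c2cc(OC)c(OC)c(OC)c2)cc1`) gives 12000 nM on the same read-out. Compound 3 (`COc1ccc(C=C(C(=O)c2cc(OC)c(OC)c(OC)c2)c2ccccc2)cc1F`) gives 790000 nM and stands second highest of the three, closer to compound 1 than to compound 2. Compound 4 (`COc1ccc(C(=Cc2ccc(OC)c(F)c2)C(=O)c2cc(OC)c(OC)c(OC)c2)cc1`) differs from compound 3 by methoxy in place of hydrogen on an aromatic carbon, para to a large group (methoxy in place of hydrogen on an aromatic carbon), phenyl to 4-methoxyphenyl. Within the data shown here, no measured step covers this change directly. Compound 1 and compound 2 both carry 4-methoxyphenyl yet span a large step (a 220-fold lower number from compound 1 to compound 2 (2.35 log units; beyond the scatter)), and compound 3 lies between them, so that group alone fixes no value. Only a moderate move to a lower number is expected (a 6.6-fold lower number from compound 3 to compound 4 (0.82 log units; beyond the scatter)) in this series. Compound 4 is estimated at 120000 nM with an expected range of 15000 nM to 700000 nM on this read-out.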

Compound 4, half-maximal inhibitory concentration: 450000 nM
For compound 4 the middle estimate is 3.8-fold (0.57 log units) below the measured one; measured number inside the range.
By their numbers in this assay, from the lowest: compound 2; then compounds 4 and 3 (each within the scatter of the next); then compound 1.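

In this assay the change from phenyl to 4-methoxyphenyl, para to a large group, gives a 1.8-fold lower number from compound 3 to compound 4 (0.24 log units; within the scatter) and so stays within the scatter. With 4-methoxyphenyl held in place, the other changed group carries the spread: fluoro in place of hydroxy gives a 38-fold higher number from compound 2 to compound 4 (1.57 log units; beyond the scatter) and fluoro in place of nitro gives a 5.9-fold lower number from compound 1 to compound 4 (0.77 log units; beyond the scatter) and compound 2 keeps the lowest number of the four. Nothing available gives a reason for these steps. Open, as far as these compounds go, is whether an amine or a carboxylic acid in place of that hydroxy would keep the number of compound 2.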